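Replacing cyclohexyl on the thioether arm: compound 4

The source may hold more compounds than are shown below. What is called first, only, known or untested is meant among the compounds shown, and "the series" means these compounds.

Working notes on the series. Compound 1 `Cc1cc(N2CC[C@@H](C)[C@@H](N(C)c3ncnc4[nH]ccc34)C2)n2nc(SCC3CCCCC3)nc2n1` carries a cyclohexyl group on a saturated chain carbon bound to a sulfur and gives 9170 nM in a functional assay on MGC-803 cells (Homo sapiens) for inhibition, read by MTT assay, with a stated time of 72 h (a lower number here means a stronger inhibitor, a higher number a weaker inhibitor), the lowest of the two numbers shown. Compound 2 `Cc1cc(N2CC[C@@H](C)[C@@H](N(C)c3ncnc4[nH]ccc34)C2)n2nc(SCc3ccc(F)c(Cl)c3)nc2n1` gives 52000 nM in this assay. Compound 3 `Cc1cc(N2CC[C@@H](C)[C@@H](N(C)c3ncnc4[nH]ccc34)C2)n2nc(SCCCc3ccccc3)nc2n1` gives only a limit of > 100000 nM in this assay and no number, the limit of > 100000 nM in this assay, at which 1 of the 3 values shown sits, case.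

The step of a 5.7-fold higher number from compound 1 to compound 2 (0.75 log units; beyond the scatter) is the closest guide. The step of an at least 10-fold higher number from compound 1 to compound 3 (1.03 log units; beyond the scatter) points the same way. Between the two aromatic variants the step of an at least 1.9-fold higher number from compound 2 to compound 3 (0.28 log units; that floor lies within the scatter) cannot be told from the scatter.

Compound 4 `Cc1ccc(CSc2nc3nc(C)cc(N4CC[C@@H](C)[C@@H](N(C)c5ncnc6[nH]ccc56)C4)n3n2)cc1` differs from compound 1 by 4-methylphenyl in place of cyclohexyl on a saturated chain carbon bound to a sulfur. Both measured steps away from cyclohexyl toward an aromatic ring raise the number, so the expectation for compound 4 is a weaker inhibitor than compound 1, with a step of about a 3.8-fold higher number from compound 1 to compound 4 (0.58 log units; beyond the scatter) expected in this assay. The estimate for compound 4 in this assay is 35000 nM, expected between 12000 nM and 100000 nM.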

Compound 4, half-maximal inhibitory concentration: 5860 nM
Compound 4: the middle estimate sits 6.0-fold (0.78 log units) above what was measured; measured number below the stated range.
By their numbers in this assay, from the lowest: compounds 4 and 1 (each within the scatter of the next); then compound 2. At a limit, above all of these: compound 3.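

An aromatic ring on this thioether arm is not a loss in itself: in this assay, 4-methylphenyl in place of cyclohexyl gives a 1.6-fold lower number from compound 1 to compound 4 (0.19 log units; within the scatter), so the two groups cannot be told apart here. The earlier reading of an aromatic replacement as weakening therefore holds for compound 2 but not for compound 4, and the two aromatic rings separate clearly, with an 8.9-fold lower number from compound 2 to compound 4 (0.95 log units; beyond the scatter). Compound 3 stands at a limit and not at a number, so an at least 17-fold lower number from compound 3 to compound 4 (1.23 log units; beyond the scatter) is only a floor: the limit of > 100000 nM in this assay, at which 1 of the 4 values shown sits.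

Whether the gap between 4-methylphenyl and 3-chloro-4-fluorophenyl follows the methyl group or the two halogens cannot be told from these compounds alone. Going by these compounds, how a plain phenyl, a 4-methoxyphenyl or a ring carrying an amine would read at this place remains open.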